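Replacing the oxazole of compound 2 with a chloromethyl oxazoline

This account rests on a few compounds, and the source may have more. Where it says the series, first, only, none or still open, it means among the compounds named here.

Compound 2 `COc1ccc(COc2ccccc2-c2cc(CO)on2)cc1` gives 64000 nM in an assay with Cystic fibrosis transmembrane conductance regulator (Rattus norvegicus) as the target (on this read-out lower numbers stand for tighter binding and higher numbers for weaker binding), the lowest of the two numbers shown; compound 1 `OCc1cc(-c2ccccc2OCc2ccc(Br)cc2)no1` gives 147000 nM, and the step of a 2.3-fold lower number from compound 1 to compound 2 (0.36 log units; beyond the scatter) follows a methoxy in place of a bromo. Compound 3 `CCCCc1cc(-c2ccccc2OCc2ccc(OC)cc2)no1` gives > 300000 nM, which is a limit of the assay. The step of an at least 4.6-fold higher number from compound 2 to compound 3 (0.67 log units; beyond the scatter) reflects (the limit of > 300000 nM in this assay, at which 1 of the 3 values shown sits). Compound 4 `COc1ccc(COc2ccccc2C2=NOC(CCl)C2)cc1` differs from compound 2 by a group of 7 heavy atoms (4 carbon, 1 nitrogen, 1 oxygen, 1 chlorine; one five-membered non-aromatic ring with 2 hetero atoms) in place of a group of 7 heavy atoms (4 carbon, 1 nitrogen, 2 oxygen; one five-membered aromatic ring with 2 hetero atoms), on an aromatic carbon. Among the compounds with values here, only the step from compound 2 to compound 3 touches this part of the molecule, and it removed the hydroxy donor with a loss; compound 4 also loses that donor, so a modest rise is expected, a 2.3-fold higher number from compound 2 to compound 4 (0.37 log units; beyond the scatter). For compound 4 the expected value is 150000 nM, between 50000 nM and 400000 nM.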

Compound 4, dissociation constant: 59000 nM
For compound 4 the middle estimate is 2.5-fold (0.41 log units) above the measured one, within the range that was stated.
By their numbers in this assay, from the lowest: compounds 4 and 2 (each within the scatter of the next); then compound 1. At a limit, above all of these: compound 3.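

In this assay, the change on an aromatic carbon, ortho to a large group, gives a 1.1-fold lower number from compound 2 to compound 4 (0.04 log units; within the scatter), so the 5-(hydroxymethyl)-1,2-oxazol-3-yl group can give way to a non-aromatic ring with 0 hydrogen-bond donors without a step beyond the scatter. Losing the hydroxy donor therefore need not raise the number, at least when the new ring and its chlorine come with that loss. Nothing measured here gives a cause for this result.

The compounds shown leave open what the ring and the chlorine each contribute on their own. They also leave open how an aminomethyl group or a carboxylic acid would read at this place.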